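Amine chain swaps on a shared flavone-type core

The source may report more compounds than this note shows. Statements on the series, on what has been measured and on what is new or still open speak of the compounds shown alone.

The compounds here share one core, varied only in the chain on an aromatic oxygen, and were compared in a functional assay on A549 cells (Homo sapiens) for cytotoxicity, read by MTT assay, with a stated time of 48 h; a lower number here means a stronger inhibitor, a higher number a weaker inhibitor. Compound 1 `COc1c(OCc2nc3ccccc3[nH]2)cc(O)c2c(=O)cc(-c3ccccc3)oc12` carries a 1H-benzimidazol-2-yl group on that chain. In this assay compound 1 reaches only the limit > 100000 nM, which is a boundary of the measurement and not a number. Compound 3 `COc1c(OCCCCN2CCCCC2)cc(O)c2c(=O)cc(-c3ccccc3)oc12` instead carries a 3-(piperidin-1-yl)propyl group, and in this assay compound 3 gives 1150 nM. That single step, an at least 86-fold lower number from compound 1 to compound 3 (1.93 log units; beyond the scatter), is the only measured one, and it is large, resting on the limit (the limit of > 100000 nM in this assay, at which 1 of the 3 values shown sits).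

Compound 2 `CCCCNCCCCOc1c(O)cc(O)c2c(=O)cc(-c3ccccc3)oc12` has a butylamino group at the end of its chain and a free hydroxyl where compounds 1 and 3 carry a methoxy; in this assay compound 2 shows "not determined" (no result reported), so compound 2 stands nowhere on the numbers shown. Compound 4 `CN(C)CCCCOc1c(O)cc(O)c2c(=O)cc(-c3ccccc3)oc12` differs from compound 2 by dimethylamino in place of butylamino on a saturated chain carbon, four bonds along the chain from an oxygen on an aromatic ring.

For the measured compounds named here, no measured step covers this change directly. Going by the values given here, the only guide is that compound 3, with a 3-(piperidin-1-yl)propyl group on its chain, gives 1150 nM, so compound 4 is estimated to land near that, at 3000 nM, within 700 nM to 15000 nM.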

Compound 4, half-maximal inhibitory concentration: > 100000 nM
Compound 4 ended at the assay's limit; the forecaster's own chance of this, stated with the estimate: 10%; at least 33-fold (1.52 log units) between middle value and limit.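

In this assay compound 4 gives > 100000 nM, which is a limit of the assay and not a number. For the compounds shown here, compound 2 has no number to set against it, so no step from compound 2 to compound 4 can be read. The compounds shown leave open whether dimethylamino in place of butylamino changes cytotoxicity at all.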